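This account rests on a few compounds, and the source may have more. Where it says the series, first, only, none or still open, it means among the compounds named here.

Compound 1 (`Cc1nc(N)c2c(-c3cccs3)cn([C@@H]3O[C@H](CO)[C@@H](O)[C@H]3O)c2n1`) gives > 20000 nM in a functional assay on CCRF-CEM cells (Homo sapiens), read by MTT assay, with a stated time of 72 h (a higher number here means a weaker inhibitor, a lower number a stronger inhibitor), which is a limit of the assay and not a number. Compound 2 (`Cc1nc(N)c2c(-c3ccsc3)cn([C@@H]3O[C@H](CO)[C@@H](O)[C@H]3O)c2n1`) gives > 20000 nM in this assay, and this too is a limit. So compound 2 has no exact standing, and the same holds for the only other compound measured: the limit of > 20000 nM in this assay, at which 2 of the 2 values shown sit. Compound 3 (`C#Cc1cn([C@@H]2O[C@H](CO)[C@@H](O)[C@H]2O)c2nc(C)nc(N)c12`) carries ethynyl in place of thiophen-3-yl on an aromatic carbon. Among the measured compounds shown here, the one measured step that bears on this change, thiophen-3-yl in place of thiophen-2-yl, is a step that the two limits leave unreadable from compound 1 to compound 2, so it offers no size to carry over. For the measured compounds named here, with only this guide, the expectation in this assay is that compound 3 stays near the limit, with a modest move towards stronger inhibition possible. The estimate amounts to an expected at least 1.3-fold lower number from compound 2 to compound 3 (0.12 log units; that floor lies within the scatter). The estimated value for compound 3 is 15000 nM, within a range of 3000 nM to 40000 nM.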

Compound 3, half-maximal inhibitory concentration: > 20000 nM
Compound 3: no number, only a limit; the forecaster's own chance of this, stated with the estimate: 60%; middle value at least 1.3-fold (0.12 log units) away from the limit.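

Compound 3 gives only a limit in this assay, so the steps linking compound 1, compound 2 and compound 3 cannot be read: the limit of > 20000 nM in this assay, at which 3 of the 3 values shown sit. The compounds shown leave open how strongly each one really inhibits, and whether swapping the group on this aromatic carbon changes that at all.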